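The compounds below may be only part of what the source reports. "The series", "measured", "known", "first", "only" and "open" are said of these compounds alone.

Compound 1 `CCOC(=O)C1=Cc2ccccc2OC1(OCc1cn(-c2ccc(F)cc2)nn1)C(F)(F)F` gives 9100 nM in a functional assay on MCF7 cells (Homo sapiens) for inhibition, read by MTT assay, with a stated time of 24 h; on this read-out higher numbers stand for weaker inhibition and lower numbers for stronger inhibition. Compound 2 `CCOC(=O)C1=Cc2ccccc2OC1(OCc1cn(CC(=O)Nc2cccc(F)c2)nn1)C(F)(F)F` reaches only the limit of this assay, > 150000 nM. Compound 3 `CCOC(=O)C1=Cc2ccccc2OC1(OCc1cn(CC(=O)Nc2ccccc2Br)nn1)C(F)(F)F` also reaches only the limit of this assay, > 150000 nM. Two of the three measured compounds thus sit at the limit of > 150000 nM in this assay, at which 2 of the 3 values shown sit, and compound 3 stands among them with no number of its own. The steps of an at least 16-fold higher number from compound 1 to compound 2 (1.21 log units; beyond the scatter) and an at least 16-fold higher number from compound 1 to compound 3 (1.21 log units; beyond the scatter) show that replacing the 4-fluorophenyl on the aromatic nitrogen by the amide-linked arrangement costs a great deal. The step that the two limits leave unreadable from compound 2 to compound 3, with both ends at the limit, cannot be sized.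

Compound 4 `CCOC(=O)C1=Cc2ccccc2OC1(OCc1cn(CC(=O)Nc2ccc(C)cc2)nn1)C(F)(F)F` differs from compound 3 in one place: 4-methylphenyl in place of 2-bromophenyl on an amide-type nitrogen. Going by the values given here, the only measured comparison of this kind, between compound 2 and compound 3, is unreadable, so it gives no direction. Both amide-linked compounds stayed at the limit, and so compound 4 is expected to do the same, with a step that the limit leaves unreadable from compound 3 to compound 4 as the expected step. Compound 4 is estimated at 200000 nM, in a range from 50000 nM to 600000 nM, most probably again reported only as a limit.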

Compound 4, half-maximal inhibitory concentration: > 150000 nM
Compound 4 was reported as a limit (the forecaster's own chance of this, stated with the estimate: 75%); the middle value is on the limit's open side.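

Replacing a halogen-bearing ring with 4-methylphenyl, which has no halogen, on the amide-type nitrogen still yields no number in this assay: compound 4 gives only a limit, and the steps from compound 2 and compound 3 to compound 4 cannot be read. Going by these compounds alone, the one readable step, an at least 16-fold higher number from compound 1 to compound 4 (1.21 log units; beyond the scatter), shows that the large gap from the directly attached 4-fluorophenyl also holds for this non-halogen ring. Three different rings on the amide-type nitrogen now share one ceiling: the limit of > 150000 nM in this assay, at which 3 of the 4 values shown sit.

These limits give no way to rank compound 2, compound 3 and compound 4 against one another. Also open, as far as these compounds go, is whether the ring or the carbamoylmethyl link matters more, which a benzyl group on the aromatic nitrogen, or an amine or carboxylic acid in place of the amide's ring, could help separate.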